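Swapping Fluoro for Methyl on a Shared Ring

The source may report more compounds than this note shows. Statements on the series, on what has been measured and on what is new or still open speak of the compounds shown alone.

Three compounds have so far been measured in a functional assay on SW480 cells (Homo sapiens) for antiproliferative activity, with a stated time of 72 h; a higher number here means a weaker inhibitor, a lower number a stronger inhibitor:

Compound 1 `O=C(COc1ccc(CNC2CC=C(c3c[nH]c4ccc(F)cc34)CC2)c(F)c1)NO` gives 179 nM.
Compound 2 `Cc1ccc2[nH]cc(C3=CCN(Cc4ccc(OCC(=O)NO)cc4F)CC3)c2c1` gives 1950 nM.
Compound 3 `O=C(COc1ccc(CN2CC=C(c3c[nH]c4ccc(F)cc34)CC2)c(F)c1)NO` gives 3860 nM.

Compound 1 gives the lowest number of the three, and its gaps to compound 2 and to compound 3 both lie beyond the usual scatter of repeated measurements. Compound 1 and compound 3 differ in more than one place, so the difference between the two cores is not broken down here.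

Compound 2 and compound 3 form a matched pair: they differ only by methyl in place of fluoro on an aromatic carbon. This change gave a 2.0-fold lower number from compound 3 to compound 2 (0.30 log units; within the scatter), a step that stays within the scatter, so the two values cannot be told apart with confidence.

Compound 4 `Cc1ccc2[nH]cc(C3=CCC(NCc4ccc(OCC(=O)NO)cc4F)CC3)c2c1` is not yet measured. Among the compounds with values here, it differs from compound 1 by methyl in place of fluoro on an aromatic carbon, which is the same change, at the same place on the shared ring, as the one between compound 3 and compound 2. On that basis the step from compound 1 to compound 4 in this assay is expected to be small, about a 1.6-fold lower number from compound 1 to compound 4 (0.21 log units; within the scatter), resting on the step of a 2.0-fold lower number from compound 3 to compound 2 (0.30 log units; within the scatter) seen in the other pair. Compound 4 is therefore estimated at 110 nM, with a likely range from 45 nM to 350 nM.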

Compound 4, half-maximal inhibitory concentration: 2780 nM
The estimate for compound 4 lay 25-fold (1.40 log units) below the measured number, outside the stated range (above it).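

In this assay, placing methyl in place of fluoro on the core of compound 1 gave a 16-fold higher number from compound 1 to compound 4 (1.19 log units; beyond the scatter), a large loss of activity for an exchange of a single heavy atom, read by name as 5-fluoro-1H-indol-3-yl to 5-methyl-1H-indol-3-yl. Set beside the same change on the other core, this step does not agree with the earlier one, and the disagreement is larger than repeated measurements would explain: the same change on two cores in this assay, a 2.0-fold lower number (0.30 log units; within the scatter) from compound 3 to compound 2 and a 16-fold higher number (1.19 log units; beyond the scatter) from compound 1 to compound 4, 31-fold (1.49 log units) apart, beyond the scatter of two such steps This shows that in this series the size of the step did not carry from one core to the other, so a step read on one core is a poor guide to the same change on the second; it does not show what in the cores produces the difference, and with only two pairs it says nothing about how the change would behave on any further core.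

The compounds shown hold only fluoro or methyl at this place, which leaves open how a chloro or a methoxy group there would read on each of the two cores. Whether such groups would also give steps that differ between the cores remains an open question.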